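Swapping the outer fluorinated ring in a stilbene diacid series

The source may hold more compounds than are shown below. What is called first, only, known or untested is meant among the compounds shown, and "the series" means these compounds.

Compound 3 `Cc1c(F)cccc1CCCCOc1ccc(/C=C/c2cccc3c(CCCC(=O)O)c(C)n(CC(=O)O)c23)cc1`, in a functional assay on the whole organism for inhibition, with Cavia porcellus as the target, with stated times of 1 h and 10 min, at a dose of 0.3 mg/kg by the oral route (on this read-out higher numbers stand for a stronger effect at the one dose given and lower numbers for a weaker effect), gives 83%, second of three measured, close to compound 2 `Cc1c(CCCC(=O)O)c2cccc(/C=C/c3ccc(OCCCCc4c(F)cc(F)c(F)c4F)cc3)c2n1CC(=O)O` with 87% and far from compound 1 `Cc1c(CCCC(=O)O)c2cccc(/C=C/c3ccc(OCCCCc4c(F)c(F)cc(F)c4F)cc3)c2n1CC(=O)O` with 9%. Compound 4 `Cc1c(CCCC(=O)O)c2cccc(/C=C/c3ccc(OCCCCc4cc(F)c(F)c(F)c4F)cc3)c2n1CC(=O)O` differs from compound 3 only at the outer ring: 2,3,4,5-tetrafluorophenyl in place of 3-fluoro-2-methylphenyl on a saturated chain carbon, four bonds along the chain from an oxygen on an aromatic ring. The step of a number 78 percentage points higher from compound 1 to compound 2 (beyond the scatter) shows that moving one fluorine of this ring is enough for a large change, while a number 4 percentage points lower from compound 2 to compound 3 (within the scatter) shows two quite different rings can give near-identical numbers. Both of these steps bear on the new pattern, but neither tests it directly. A modest drop is expected, with wide uncertainty: compound 4 is estimated at 60%, within 15% to 90%, meaning an expected step of a number 23 percentage points lower from compound 3 to compound 4 (beyond the scatter).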

Compound 4, a percentage reported as inhibition, in the whole organism at one dose (the size of the read-out at that dose, not a potency): 55%
Compound 4: middle estimate off by 5 percentage points, on the high side; low and high end bracket the measured number.
By their numbers in this assay, from the lowest: compound 1; then compound 4; then compounds 3 and 2 (each within the scatter of the next).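

With three tetrafluorophenyl patterns now compared, the placing of the fluorines on this ring separates all three compounds at this single dose: a number 32 percentage points lower from compound 2 to compound 4 (beyond the scatter), and a number 46 percentage points higher from compound 1 to compound 4 (beyond the scatter). The 2,3,4,5-tetrafluorophenyl ring also falls short of the 3-fluoro-2-methylphenyl ring, a number 28 percentage points lower from compound 3 to compound 4 (beyond the scatter), so the close match between compound 2 and compound 3 does not extend to every ring here. No measurement shown explains these differences.

From the compounds shown here alone, whether a plain phenyl or a 4-fluorophenyl ring on this chain would keep the effect remains open. So does the effect of a pentafluorophenyl ring.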